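Swapping a Chloro Group for a Hydroxymethyl Group

The source may hold more compounds than are shown below. What is called first, only, known or untested is meant among the compounds shown, and "the series" means these compounds.

Of the compounds shown here, three sharing one core have been tested in an assay on membranes from brain for displacement of a labelled ligand from Neuronal acetylcholine receptor; alpha4/beta2 (Rattus norvegicus); on this read-out higher numbers stand for weaker inhibition and lower numbers for stronger inhibition. Compound 1 `CCc1cncc(OC[C@@H]2CCCN2C)c1` gives 0.32 nM. Compound 2 `CN1CCC[C@H]1COc1ccc(F)nc1` gives 2.56 nM, and compound 3 `CN1CCC[C@H]1COc1ccc(Cl)nc1` gives 0.64 nM. Within the data shown here, the only single-point comparison among them is the halogen swap: a 4.0-fold lower number from compound 2 to compound 3 (0.60 log units; beyond the scatter). Compound 3 therefore holds the second highest of the three numbers, within the scatter of compound 1 and separated from compound 2 by a step beyond it.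

Compound 4 `CN1CCC[C@H]1COc1ccc(CO)nc1` differs from compound 3 in one place: hydroxymethyl in place of chloro on an aromatic carbon. Among the measured compounds shown here, no measured pair replaces a halogen with a group carrying a hydrogen-bond donor and acceptor, so the data give no direct guide. The step from compound 2 to compound 3 shows only that what sits on this aromatic carbon can shift the number by a modest amount in this assay. Because a 4.0-fold lower number from compound 2 to compound 3 (0.60 log units; beyond the scatter) already shows such sensitivity, a change of similar size is plausible here, and with the new group unlike either halogen the expected direction is toward a higher number, that is weaker inhibition. Compound 4 is therefore estimated at 3 nM, with a range from 0.8 nM to 12 nM, meaning an expected step of a 4.7-fold higher number from compound 3 to compound 4 (0.67 log units; beyond the scatter).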

Compound 4, inhibition constant: 97.4 nM
For compound 4 the middle estimate is 32-fold (1.51 log units) below the measured one, outside the stated range (above it).
By their numbers in this assay, from the lowest: compounds 1 and 3 (each within the scatter of the next); then compound 2; then compound 4.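

In this assay, the aromatic carbon next to the ring nitrogen proves far more demanding than the two halogens suggested. Hydroxymethyl in place of chloro gives a 150-fold higher number from compound 3 to compound 4 (2.18 log units; beyond the scatter) and hydroxymethyl in place of fluoro gives a 38-fold higher number from compound 2 to compound 4 (1.58 log units; beyond the scatter), both large steps that dwarf the modest halogen swap, a 4.0-fold lower number from compound 2 to compound 3 (0.60 log units; beyond the scatter), so the earlier pair showed only a small part of how much this position can move the number. Hydroxymethyl brings 1 hydrogen-bond donor and 1 hydrogen-bond acceptor where chloro has none, but nothing available shows whether these or some other difference accounts for the jump.

The compounds shown leave open whether the step belongs to the oxygen and its hydrogen or to the added carbon, a question that a methyl group, a methoxy group or an amine at this carbon could help to separate. They also leave open whether a longer chain ending in a hydroxyl group, or a carboxylic acid, would give a number closer to those of the halogens or one higher still.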